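The source may hold more compounds than are shown below. What is called first, only, known or untested is meant among the compounds shown, and "the series" means these compounds.

Measured so far:
compound 1 `Cc1ccc(N2CCN(c3cc(C(F)(F)F)ccc3CNC(=O)C(C)c3ccc(NS(C)(=O)=O)c(F)c3)CC2)cc1` gives 0.7 nM in an assay on CHO cells for antagonist activity at transient receptor potential cation channel subfamily V member 1 (Homo sapiens), read by FLIPR; a higher number here means a weaker inhibitor, a lower number a stronger inhibitor.
compound 2 `CCCCSc1cc(C(F)(F)F)ccc1CNC(=O)C(C)c1ccc(NS(C)(=O)=O)c(F)c1` gives 1.9 nM in this assay.

Compound 2 holds the higher of the two numbers in this assay; its nearest neighbour is compound 1, whose number sits lower by a gap beyond the usual scatter. Among the measured compounds shown here, no pair of measured compounds differs in a single place, so the reading of compound 3 `COc1cc(OC)cc(-c2cc(C(F)(F)F)ccc2CNC(=O)C(C)c2ccc(NS(C)(=O)=O)c(F)c2)c1` rests on the change itself and on the two values. The change from compound 2 to compound 3 is 3,5-dimethoxyphenyl in place of butylsulfanyl on an aromatic carbon. Compound 1 carries a larger group on the shared core and gives 0.7 nM, so a larger group at this end of the series is compatible with a low number. A modest downward step, or none beyond the scatter, is expected in this assay, namely a 1.3-fold lower number from compound 2 to compound 3 (0.10 log units; within the scatter). Compound 3 is estimated at 1.5 nM, with a range from 0.5 nM to 4.5 nM.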

Compound 3, inhibition constant: 5.8 nM
Compound 3: the middle estimate sits 3.9-fold (0.59 log units) below what was measured; measured number outside the range, above it.
By their numbers in this assay, from the lowest: compound 1; then compound 2; then compound 3.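

In this assay, among the compounds shown here, 3,5-dimethoxyphenyl in place of butylsulfanyl on an aromatic carbon, ortho to a large group and meta to a trifluoromethyl group, gives a 3.1-fold higher number from compound 2 to compound 3 (0.48 log units; beyond the scatter), the first single-place step. With compound 3 at 5.8 nM, the position accepts this aromatic ring with a modest loss, so swapping the open sulfur-linked chain for the larger ring does not remove activity in this assay. No measurement shown here accounts for the direction or the size of this step.

Still open, from the compounds shown here alone, is whether the step follows from the aromatic ring itself or from its two methoxy groups. A plain phenyl would separate those two readings, and a longer alkylsulfanyl chain or a carboxylic acid at this position would test how far the trend extends.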